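This account rests on a few compounds, and the source may have more. Where it says the series, first, only, none or still open, it means among the compounds named here.

Within the data shown here, compound 2 `N#Cc1ccc(-c2cn(CC(=O)Nc3nccs3)nn2)cc1` carries the lower of the two numbers measured so far in a functional assay on BMDM cells (Mus musculus, strain C57BL/6) for inhibition, with a stated time of 2 days; a lower number here means a stronger inhibitor, a higher number a weaker inhibitor: compound 2 gives 270 nM, while compound 1 `COc1ccc(-c2cn(CC(=O)Nc3nccs3)nn2)cc1` gives 510 nM. The gap between them, a 1.9-fold lower number from compound 1 to compound 2 (0.28 log units; within the scatter), lies within the scatter, so the two cannot truly be ordered. Compound 3 `C#Cc1ccc(-c2cn(CC(=O)Nc3nccs3)nn2)cc1` has not yet been measured; it differs from compound 2 by ethynyl in place of cyano on an aromatic carbon. Among the measured compounds shown here, only one measured step bears on this, a 1.9-fold lower number from compound 1 to compound 2 (0.28 log units; within the scatter), a swap of a different group on an aromatic carbon, and it did not move the number beyond the scatter. For the measured compounds named here, no measured step involves ethynyl, so the sole guide is that a swap on this aromatic carbon has so far left the number about where it was. Compound 3 is therefore expected to show a step of a 1.3-fold higher number from compound 2 to compound 3 (0.11 log units; within the scatter) in this assay, nothing beyond the scatter. Compound 3 is estimated at 350 nM, within a range from 150 nM to 800 nM.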

Compound 3, half-maximal inhibitory concentration: > 30000 nM
Compound 3 ended at the assay's limit (the forecaster's own chance of this, stated with the estimate: 5%); middle value at least 85-fold (1.93 log units) away from the limit.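

This position is less forgiving than the earlier pair suggested: in this assay, ethynyl in place of cyano gives an at least 110-fold higher number from compound 2 to compound 3 (2.04 log units; beyond the scatter), and ethynyl in place of methoxy gives an at least 58-fold higher number from compound 1 to compound 3 (1.76 log units; beyond the scatter). Cyano and ethynyl have the same count of heavy atoms and each holds a triple bond outside the aromatic ring, yet exchanging them on this aromatic carbon moves the number far beyond the scatter. Compound 3 stands at a limit of the assay, not at an exact number: the limit of > 30000 nM in this assay, at which 1 of the 3 values shown sits.

Among these compounds, with only three compounds, it remains unclear whether the loss of the nitrogen and its hydrogen-bond acceptor matters or whether something else about ethynyl is responsible. From the compounds shown here alone, how an amine, a carboxylic acid or a longer chain would fare on this aromatic carbon also stays open.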